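A few compounds are considered here, and "the series" means these few. Any claim that something is new, unique, unknown or untested is made for them only; others in the source may bear on it.

In a functional assay on the whole organism with Rattus norvegicus as the target (on this read-out higher numbers stand for an effect only at larger amounts of compound and lower numbers for an effect already at smaller amounts), compound 1 `CC(C)(C)Oc1ccc2nc(N)sc2c1` gives > 10 mg/kg, which is a limit of the assay and not a number. Among the measured compounds shown here, compound 2 `CCCCn1c(=N)sc2cc(OC(F)(F)F)ccc21` reads 10 mg/kg, the only true number so far. The evidence is thin, and it amounts to this: the limit of > 10 mg/kg in this assay, at which 1 of the 2 values shown sits.

Compound 3 `N=c1sc2cc(OC(F)(F)F)ccc2n1CC(=O)O` keeps the shared core of compound 2 and alters only the chain, with carboxy in place of propyl on a saturated chain carbon bound to an aromatic nitrogen. Read one bond further out, this is butyl to carboxymethyl. For the measured compounds named here, no measured pair of compounds differs in one place, so this step has no direct precedent. Starting from compound 2 at 10 mg/kg, a move beyond the usual scatter towards larger doses is expected, though this remains a tentative judgement. The estimated move is a 3.0-fold higher number from compound 2 to compound 3 (0.48 log units; beyond the scatter). For compound 3 the expected dose is 30 mg/kg, with an estimated range from 10 mg/kg to 90 mg/kg.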

Compound 3, dose for half-maximal effect: > 10 mg/kg
Compound 3: no number, only a limit (the forecaster's own chance of this, stated with the estimate: 50%); the middle value lies beyond the limit too.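

The value of compound 3, > 10 mg/kg, is a limit of the assay and not a number. Carboxy in place of propyl on a saturated chain carbon bound to an aromatic nitrogen is the first change at this place that can be read, and in this assay it gives a number no lower from compound 2 to compound 3 (the limit leaves the size open), so this swap did not bring an effect at a smaller dose. How far the number moved cannot be read, and the data so far offer few true numbers to set it against: the limit of > 10 mg/kg in this assay, at which 2 of the 3 values shown sit.

Still open, from the compounds shown here alone, is whether the loss, if there is one, comes from the carboxy group itself or from the shorter chain that carries it. An amine, an amide or a longer chain at this same place could show whether any group here gives a clearly lower number than compound 2.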